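This account rests on a few compounds, and the source may have more. Where it says the series, first, only, none or still open, it means among the compounds named here.

Measured so far in a functional assay on A549 cells (Homo sapiens) for inhibition, read by sulforhodamine B assay, with a stated time of 72 h; on this read-out lower numbers stand for stronger inhibition and higher numbers for weaker inhibition:
- compound 1 `COc1cc2c(Nc3ccc(F)c(Cl)c3)ncnc2cc1OCCCn1ccnc1[N+](=O)[O-]` gives 5910 nM here
- compound 2 `COc1cc2c(Nc3ccc(F)c(Cl)c3)ncnc2cc1OCCOCCn1ccnc1[N+](=O)[O-]` gives 12900 nM here
- compound 3 `COc1cc2c(Nc3ccc(OCc4cccc(F)c4)c(Cl)c3)ncnc2cc1OCCCn1ccnc1[N+](=O)[O-]` gives 3970 nM here

Compound 1 holds the second highest of these three numbers. Its nearest neighbour lies at a 1.5-fold lower number from compound 1 to compound 3 (0.17 log units; within the scatter) and its furthest at a 2.2-fold higher number from compound 1 to compound 2 (0.34 log units; beyond the scatter) on the numbers shown.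

Compound 4 `COc1cc2c(Nc3cccc(Br)c3)ncnc2cc1OCCCn1ccnc1[N+](=O)[O-]` has not yet been measured. It differs from compound 1 by 3-bromophenyl in place of 3-chloro-4-fluorophenyl on a nitrogen on an aromatic ring and keeps the rest of the structure, so 3-bromophenyl stands in place of 3-chloro-4-fluorophenyl on a nitrogen on an aromatic ring.

Among the compounds with values here, no measured compound carries 3-bromophenyl, so the data offer no direct reading of this group. The step along the chain does not touch the group that changes here and gives little guidance. Within the data shown here, the only measured change to the 3-chloro-4-fluorophenyl group is a 1.5-fold lower number from compound 1 to compound 3 (0.17 log units; within the scatter) in the present series, and there (3-fluorobenzyl)oxy replaces fluoro. On that evidence, no change beyond the scatter is expected in this assay for the smaller swap, and the estimated step is a 1.0-fold higher number from compound 1 to compound 4 (0.01 log units; within the scatter) in this case. The estimate for compound 4 is 6000 nM with 2500 nM to 14000 nM as its expected range.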

Compound 4, half-maximal inhibitory concentration: 13500 nM
Compound 4: middle estimate off by 2.3-fold (0.35 log units), on the low side; measured number inside the range.
By their numbers in this assay, from the lowest: compounds 3 and 1 (each within the scatter of the next); then compounds 2 and 4 (each within the scatter of the next).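

In this assay, the swap of 3-chloro-4-fluorophenyl for 3-bromophenyl on the nitrogen gives a 2.3-fold higher number from compound 1 to compound 4 (0.36 log units; beyond the scatter), so this group can shift the number beyond the scatter, which the earlier change within it, a 1.5-fold lower number from compound 1 to compound 3 (0.17 log units; within the scatter), did not do. The shift is modest, and it comes with one heavy atom fewer and with the counts of hydrogen-bond donors, hydrogen-bond acceptors and net charge unchanged, since the fluorine leaves and bromine stands where chlorine stood. No evidence is at hand to explain the step.

Because the swap changes two halogens at once, this single step cannot say how much belongs to the loss of fluorine and how much to bromine in place of chlorine, and a 3-chlorophenyl or a 4-fluorophenyl group on the same nitrogen would be needed to separate the two. Going by these compounds, it also stays open whether the step would be the same size with the 2-(2-nitro-1H-imidazol-1-yl)ethoxy chain of compound 2 in place of the shorter chain of compound 1.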